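A few compounds are considered here, and "the series" means these few. Any claim that something is new, unique, unknown or untested is made for them only; others in the source may bear on it.

In a functional assay on PBMC cells (Homo sapiens) for inhibition, read by HTRF, with stated times of 15 min and 24 h (a higher number here means a weaker inhibitor, a lower number a stronger inhibitor), the measured compounds stand as follows:
Compound 1 `O=C(Nc1ccc2c(c1)B(O)OC2)c1ccccc1F` gives > 10000 nM, a limit of the assay rather than a number.
Compound 2 `O=C(Nc1ccc2c(c1)B(O)OC2)c1ccccc1Cl` gives > 100000 nM, also a limit.
Compound 3 `O=C(Nc1ccc2c(c1)B(O)OC2)c1ccccc1OC(F)(F)F` gives > 100000 nM, again a limit.

Compound 2 therefore sits at the limit of > 100000 nM in this assay, at which 2 of the 3 values shown sit, and nothing in this assay separates it from the other two. The change from compound 2 to compound 4 `O=C(Nc1ccc2c(c1)B(O)OC2)c1c(F)cccc1Cl` is fluoro in place of hydrogen on an aromatic carbon. Of the measured steps, a step that the two limits leave unreadable from compound 1 to compound 2, a step that the two limits leave unreadable from compound 2 to compound 3 and a step that the two limits leave unreadable from compound 1 to compound 3 all have a limit at each end, so none of them shows a readable size or direction. No step beyond the scatter is therefore expected, and the step from compound 2 to compound 4 is estimated at a number no higher from compound 2 to compound 4 (the limit leaves the size open). Compound 4 is expected to give 100000 nM, within 30000 nM to 300000 nM, most likely reported again as a limit.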

Compound 4, half-maximal inhibitory concentration: 4900 nM
The estimate for compound 4 lay 20-fold (1.31 log units) above the measured number; measured number below the stated range.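

The step that puts fluoro in place of hydrogen on an aromatic carbon, ortho to a large group and meta to a chloro group, is in this assay an at least 20-fold lower number from compound 2 to compound 4 (1.30 log units; beyond the scatter), so a single change at this position can move the number far. Chloro in place of hydrogen gives an at least 2.0-fold lower number from compound 1 to compound 4 (0.30 log units; that floor lies within the scatter), a floor that does not by itself show a real gain. Compound 2 gives > 100000 nM, a limit, so the larger step is also only a floor: the limit of > 100000 nM in this assay, at which 2 of the 4 values shown sit.

Going by these compounds, whether an amine or a methoxy group at this position would match fluoro remains open.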